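Shortening the ether linker: from compound 1 to compound 4

The source may hold more compounds than are shown below. What is called first, only, known or untested is meant among the compounds shown, and "the series" means these compounds.

In an assay on cells for inhibition of Amine oxidase [flavin-containing] B (Homo sapiens), read by fluorescence, with stated times of 30 min and 15 min, tested at 1 uM (on this read-out higher numbers stand for more inhibition at the one concentration tested (going by the name of the read-out) and lower numbers for less inhibition), compound 1 `Cn1c(=O)[nH]c2cc(OCCCc3ccccc3)ccc21` is reported as "not active" (no number reported) with no number behind it, so it stands at the weak end of the read-out without a value to anchor it. Compound 2 `CC1(C)C(=O)Nc2ccc(OCc3cccc(Cl)c3)cc21` gives 21.1% in this assay, and compound 3 `CC(C)n1c(=O)[nH]c2ccc(OCCOc3cccc(F)c3)cc21` gives 12.9%; both are small, and the gap between them lies within the usual scatter. Compound 4 `Cn1c(=O)[nH]c2cc(OCCc3ccccc3)ccc21` differs from compound 1 by phenyl in place of benzyl on a saturated chain carbon, two bonds along the chain from an oxygen on an aromatic ring. For the measured compounds named here, no measured pair in the set shows a step of this kind, so no direction beyond the scatter can be taken from the numbers; a move no larger than the scatter, either way, is expected in this assay. Compound 4 is expected to give about 10% in this assay, estimated within 0% to 30%.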

Compound 4, a percentage reported as inhibition, at one concentration (the size of the read-out at that concentration, not a potency): "not active" (no number reported)
The entry for compound 4 holds no number; there is nothing to compare the estimate with.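

Compound 1 and compound 4 both stand without a number, so no step can be read between them. The compounds shown leave open whether phenyl in place of benzyl shifts inhibition at all. No evidence bears on this result.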